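A few compounds are considered here, and "the series" means these few. Any claim that something is new, unique, unknown or untested is made for them only; others in the source may bear on it.

Compound 1, `COc1cc(OC)c2sc(-c3ccc(N/C=C\C(=O)c4ccc(OC)c(O)c4)c(C)c3)nc2c1`, and compound 2, `COc1cc(OC)c2sc(-c3ccc(N/C=C\C(=O)c4ccc(OC)c([N+](=O)[O-])c4)c(C)c3)nc2c1`, share one core and differ in a single spot: nitro in place of hydroxy on an aromatic carbon. In a functional assay on HeLa cells (Homo sapiens) for antiproliferative activity, read by sulforhodamine B assay, with a stated time of 48 h (on this read-out higher numbers stand for weaker inhibition and lower numbers for stronger inhibition), compound 1 gives 16100 nM, while compound 2 gives 9390 nM, so that a 1.7-fold lower number from compound 1 to compound 2 (0.23 log units; within the scatter).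

Compound 3, `COc1ccc2nc(-c3ccc(N/C=C\C(=O)c4ccc(OC)c(O)c4)cc3)sc2c1`, carries a different core from compound 1 together with the same 3-hydroxy-4-methoxyphenyl group; how the two cores differ is not broken down here. In this assay compound 3 gives 6900 nM, which sits within the scatter of the number for compound 2 and beyond the scatter of the number for compound 1.

Compound 4, `COc1ccc2nc(-c3ccc(N/C=C\C(=O)c4ccc(OC)c([N+](=O)[O-])c4)cc3)sc2c1`, has not yet been measured. It stands to compound 3 as compound 2 stands to compound 1: nitro in place of hydroxy on an aromatic carbon. Among the compounds with values here, the change is the same as the one between compound 1 and compound 2, with the same surroundings on the ring, and so the single earlier step is the only guide. Because a 1.7-fold lower number from compound 1 to compound 2 (0.23 log units; within the scatter) was small and within the scatter, the step from compound 3 to compound 4 is expected to be of a similar modest size, with a slightly lower number the likeliest outcome, namely a 1.5-fold lower number from compound 3 to compound 4 (0.19 log units; within the scatter). On that basis compound 4 is estimated to give 4500 nM in this assay, with the likely range running from 2000 nM to 10000 nM.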

Compound 4, half-maximal inhibitory concentration: 17600 nM
Beside the measured number, compound 4's estimate is 3.9-fold (0.59 log units) below it; the whole stated range lies below it.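

In this assay, putting nitro in place of hydroxy on the core of compound 3 gives a 2.6-fold higher number from compound 3 to compound 4 (0.41 log units; beyond the scatter), which means weaker inhibition by a margin that lies beyond the scatter, whereas the same change on the core of compound 1 gave a 1.7-fold lower number from compound 1 to compound 2 (0.23 log units; within the scatter), a shift that cannot be told from repeat measurement. Set side by side, the two results show that the effect of this change does not carry over unchanged from one core to the other, even though the surroundings on the ring are the same: the same change on two cores in this assay, a 1.7-fold lower number (0.23 log units; within the scatter) from compound 1 to compound 2 and a 2.6-fold higher number (0.41 log units; beyond the scatter) from compound 3 to compound 4, 4.4-fold (0.64 log units) apart, beyond the scatter of two such steps. This rests on a single pair on each core, and the cores differ in more than one place, so it shows neither which feature of the cores matters nor why the outcome differs, and it gives no rule for any further core.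

The compounds shown leave open how an amine or a carboxylic acid in place of the hydroxy would behave on either core, and whether such groups would also depend on the core. They also leave open whether a longer chain in place of the methoxy group would alter the difference between the two cores.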